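Benzyl-type swap on the sulfur chain: compound 3 to 4

This account rests on a few compounds, and the source may have more. Where it says the series, first, only, none or still open, it means among the compounds named here.

Measured in a functional assay on MGC-803 cells (Homo sapiens) for inhibition, read by MTT assay, with a stated time of 72 h; on this read-out lower numbers stand for stronger inhibition and higher numbers for weaker inhibition:
- compound 1 `Cc1cc(N2CC[C@@H](C)[C@@H](N(C)c3ncnc4[nH]ccc34)C2)n2nc(SCC3CC3)nc2n1`: 9540 nM
- compound 2 `C[C@@H]1CCN(c2cc(-c3ccccc3)nc3ncnn23)C[C@@H]1N(C)c1ncnc2[nH]ccc12`: 84900 nM
- compound 3 `Cc1cc(N2CC[C@@H](C)[C@@H](N(C)c3ncnc4[nH]ccc34)C2)n2nc(SCc3csc4ccc(Cl)cc34)nc2n1`: > 100000 nM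

Compound 3 stands at a limit of the assay and not at a number: > 100000 nM. This is the limit of > 100000 nM in this assay, at which 1 of the 3 values shown sits.

Compound 4 `Cc1ccc(CSc2nc3nc(C)cc(N4CC[C@@H](C)[C@@H](N(C)c5ncnc6[nH]ccc56)C4)n3n2)cc1` has not yet been measured. The change is 4-methylphenyl in place of 5-chloro-1-benzothiophen-3-yl on a saturated chain carbon bound to a sulfur.

Going by the values given here, one measured step bears on this place: an at least 10-fold higher number from compound 1 to compound 3 (1.02 log units; beyond the scatter), with 5-chloro-1-benzothiophen-3-yl in place of cyclopropyl. Of the two compounds compared in that step, only compound 1 gives a number, 9540 nM. A single step is thin support, and the limit leaves the starting point open. A move to a lower number is still expected, of moderate size and possibly not far from the limit. The expected change is an at least 3.3-fold lower number from compound 3 to compound 4 (0.52 log units; beyond the scatter) in this assay. For compound 4 the estimated value is 30000 nM, with an expected range of 8000 nM to 100000 nM.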

Compound 4, half-maximal inhibitory concentration: 5860 nM
The estimate for compound 4 lay 5.1-fold (0.71 log units) above the measured number; measured number outside the range, below it.
By their numbers in this assay, from the lowest: compounds 4 and 1 (each within the scatter of the next); then compound 2. At a limit, above all of these: compound 3.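

In this assay, the step to 4-methylphenyl on a saturated chain carbon bound to a sulfur gives an at least 17-fold lower number from compound 3 to compound 4 (1.23 log units; beyond the scatter), so the loss seen with 5-chloro-1-benzothiophen-3-yl does not extend to every aromatic group at this place. Compound 3 stands at a limit and not at a number, so that step gives only a minimum size: the limit of > 100000 nM in this assay, at which 1 of the 4 values shown sits. Set against cyclopropyl, 4-methylphenyl gives a 1.6-fold lower number from compound 1 to compound 4 (0.21 log units; within the scatter), so this read-out does not separate the two groups, and a single six-membered aromatic ring is accepted here.

The compounds shown do not separate the contribution of the chlorine from that of the fused ring pair in 5-chloro-1-benzothiophen-3-yl. On these data alone, how this position responds to an amine, a carboxylic acid or a longer chain on the sulfur also remains open.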